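The source may hold more compounds than are shown below. What is called first, only, known or untested is meant among the compounds shown, and "the series" means these compounds.

Measured so far in a functional assay on Bel-7402 cells (Homo sapiens) for cytotoxicity, read by MTT assay, with a stated time of 48 h; on this read-out higher numbers stand for weaker inhibition and lower numbers for stronger inhibition:
- Compound 1 `COc1cc(-n2c(-c3ccc(O)cc3)c[nH]c2=O)cc(OC)c1OC`: > 50000 nM
- Compound 2 `COc1ccc(-c2c[nH]c(=O)n2-c2cc(OC)c(OC)c(OC)c2)cc1[N+](=O)[O-]`: "not determined" (no result reported)
- Compound 3 `COc1cc(NC(=O)n2cc(-c3ccc(O)cc3)n(-c3cc(OC)c(OC)c(OC)c3)c2=O)cc(OC)c1OC`: > 50000 nM

Compound 3 gives > 50000 nM, and this is a limit of the assay, not a number. Compound 1 gives > 50000 nM, which is also a limit. Compound 2 has no usable result, recorded as "not determined" (no result reported). The measured picture is therefore (the limit of > 50000 nM in this assay, at which 2 of the 3 values shown sit). No exact potency is available for any of these compounds, and no measured step links any two of them.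

The next compound, compound 4 `COc1ccc(-c2cn(C(=O)Nc3cc(OC)c(OC)c(OC)c3)c(=O)n2-c2cc(OC)c(OC)c(OC)c2)cc1OC`, differs from compound 3 in one place. It carries 3,4-dimethoxyphenyl in place of 4-hydroxyphenyl on an aromatic carbon. The rest of the structure is unchanged.

Among the compounds with values here, with no measured step to borrow a size from, the expectation in this assay is for no change beyond the usual scatter, and no direction can be favoured with confidence. This expectation rests on compound 3, whose result is the limit > 50000 nM. The expected step is an at least 1.1-fold lower number from compound 3 to compound 4 (0.04 log units; that floor lies within the scatter). For compound 4 the estimated value is 45000 nM, with an expected range from 10000 nM to 100000 nM.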

Compound 4, half-maximal inhibitory concentration: > 50000 nM
Compound 4: no number, only a limit (the forecaster's own chance of this, stated with the estimate: 65%); at least 1.1-fold (0.04 log units) between middle value and limit.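

In this assay compound 4 gives > 50000 nM and this is a limit of the assay, not a number. Within the data shown here, compound 3 also sits at a limit, and no step between compound 3 and compound 4 can be read. The compounds shown leave open how strongly any of them inhibits these cells, and whether replacing 4-hydroxyphenyl with 3,4-dimethoxyphenyl changes that inhibition.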